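Methyl removal on the ring of compound 3

A few compounds are considered here, and "the series" means these few. Any claim that something is new, unique, unknown or untested is made for them only; others in the source may bear on it.

Three amidine thiosemicarbazide analogues have numbers in a functional assay on A-375 cells (Homo sapiens) for cytotoxicity, read by MTT assay, with a stated time of 72 h, tested at 30 uM (a lower number here means less inhibition of growth, a higher number more inhibition of growth at the concentration tested), so far. Compound 1 `Cc1cccc(/C(N)=N/NC(=S)N2CCN(c3ccccn3)CC2)n1` gives 74.8%, compound 2 `N/C(=N\NC(=S)N1CCN(c2ccccn2)CC1)c1ccc(F)cn1` gives 73.2%, and compound 3 `Cc1cccc(/C(N)=N/NC(=S)N2CCSCC2)n1` gives 73.1%. Within the data shown here, the single one-place step, a number 1.6 percentage points lower from compound 1 to compound 2 (within the scatter), shows that exchanging the group on the carbon that carries the amidine leaves this assay unchanged. Compound 3 sits within the scatter of both compound 2 and compound 1, so none of the three can be ordered against the others.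

Compound 4 `N/C(=N\NC(=S)N1CCSCC1)c1ccccn1` follows from compound 3 by hydrogen in place of methyl on an aromatic carbon. No measured step removes a methyl from this six-membered aromatic ring with 1 nitrogen; the one step that alters this ring at all, from compound 1 to compound 2, stayed within the scatter, and the series has so far shown no movement in this assay. The expectation is therefore a step of no size beyond the scatter, a number 2.1 percentage points lower from compound 3 to compound 4 (within the scatter). Compound 4 is estimated at 71%, with a range from 58% to 82%.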

Compound 4, percent growth inhibition at one concentration: 86%
Estimate against measurement, compound 4: 15 percentage points below; the measured number lies above the stated range.
By their numbers in this assay, from the lowest: compounds 3, 2 and 1 (each within the scatter of the next); then compound 4.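

In this assay the position next to the ring nitrogen is not silent: a number 12.9 percentage points higher from compound 3 to compound 4 (beyond the scatter) is the first step beyond the scatter among the compounds shown, and it comes from hydrogen in place of methyl alone. The loss of that methyl does not give such a step in every setting, as a number 1.6 percentage points lower from compound 1 to compound 2 (within the scatter) also takes away the methyl, while fluorine enters with 5-fluoropyridin-2-yl, and this step stays within the scatter. Nothing shown bears on why hydrogen at this position gives more inhibition of growth than methyl.

From the compounds shown here alone, whether the gain belongs to hydrogen alone or would also hold with fluorine, a methoxy group or an amine at this position remains open. Also open, going by these compounds, is whether the same removal of methyl from compound 1, with its different group on the far side of the thiocarbonyl, would give a step of similar size.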